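Removing a methoxy group: notes toward compound 4

The source may hold more compounds than are shown below. What is called first, only, known or untested is meant among the compounds shown, and "the series" means these compounds.

Measured so far in a functional assay on EA.hy 926 cells (Homo sapiens) for cytotoxicity, read by MTT assay, with stated times of 24 h and 12 h; a lower number here means that less compound is needed, a higher number that more compound is needed for the effect:
- compound 1 `COc1ccc(/C=C/C(=O)O)cc1OC(=O)c1nc(C)c(C)nc1C` gives 8800 nM
- compound 2 `CCOC(=O)/C=C/c1cc(OC)ccc1OC(=O)c1nc(C)c(C)nc1C` gives 105000 nM
- compound 3 `Cc1nc(C)c(C(=O)Oc2cccc(/C=C/C(=O)O)c2)nc1C` gives 24000 nM

Compound 2 has the highest number of the three in this assay; the difference between the core of compound 1 and the core of compound 2 is not broken down here.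

One change has been measured once: from compound 1 to compound 3, (hydrogen in place of methoxy on an aromatic carbon), giving a 2.7-fold higher number from compound 1 to compound 3 (0.44 log units; beyond the scatter).

Compound 4 `CCOC(=O)/C=C/c1ccccc1OC(=O)c1nc(C)c(C)nc1C` is not yet measured. It differs from compound 2 by hydrogen in place of methoxy on an aromatic carbon. The surroundings differ from the earlier pair: there the site was ortho to a large group and para to a 2-carboxyethenyl group, here it is meta to a 2-(ethoxycarbonyl)ethenyl group and para to a large group, so this is the same kind of change, not the same change.

Resting on the single earlier step, a 2.7-fold higher number from compound 1 to compound 3 (0.44 log units; beyond the scatter), a step of like size and direction is expected for compound 4, a 2.5-fold higher number from compound 2 to compound 4 (0.39 log units; beyond the scatter), with wide uncertainty given one precedent and the high starting number of compound 2, 105000 nM. Compound 4 is therefore estimated at 260000 nM in this assay, within 100000 nM to 650000 nM.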

Compound 4, half-maximal effective concentration: 108000 nM
Estimate against measurement, compound 4: 2.4-fold (0.38 log units) above, within the range that was stated.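

In this assay the new step is a 1.0-fold higher number from compound 2 to compound 4 (0.01 log units; within the scatter), so on the core of compound 2, with its 2-(ethoxycarbonyl)ethenyl group, hydrogen in place of methoxy gives no readable change. Among the compounds shown here, this does not establish that the change carries over from core to core with a fixed size, since it rests on only two pairs, and the step on the core of compound 1 lies beyond the scatter while the new one lies within it. Nor does it establish that the cores respond differently, since the two steps cannot be told apart: the same change on two cores in this assay, a 2.7-fold higher number (0.44 log units; beyond the scatter) from compound 1 to compound 3 and a 1.0-fold higher number (0.01 log units; within the scatter) from compound 2 to compound 4, 2.7-fold (0.42 log units) apart, within the scatter of two such steps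

The compounds shown leave open whether an amine at the site of the methoxy group would give a readable step on either core. They also leave open whether a longer chain in place of the ethyl group of the ester would change the number for compound 2 or compound 4, and whether any such step would carry across both cores.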